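Vinyl-chain oximes on a pyrimidinedione core

This account rests on a few compounds, and the source may have more. Where it says the series, first, only, none or still open, it means among the compounds named here.

Two compounds of this set have been run in a functional assay on HeLa cells (Homo sapiens) for inhibition (a higher number here means a weaker inhibitor, a lower number a stronger inhibitor), and both returned only a limit of the assay rather than a number. Compound 1, `Nc1nc(O)c2ncn(/C=C/C=O)c2n1`, is the purine-type member; in this assay compound 1 gives > 100000 nM, which is a limit. Compound 2, `Cc1cn(/C=C/C#N)c(=O)[nH]c1=O`, carries a cyano group on the vinyl chain; in this assay compound 2 gives > 100000 nM, again a limit. Compound 2 thus stands at the limit of > 100000 nM in this assay, at which 2 of the 2 values shown sit, with no numeric value to rank it against anything else in the set.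

Compound 3, `Cc1cn(/C=C/C=N/O)c(=O)[nH]c1=O`, is the next member to be measured. Relative to compound 2 the change is a group of 3 heavy atoms (1 carbon, 1 nitrogen, 1 oxygen; no ring) in place of a group of 2 heavy atoms (1 carbon, 1 nitrogen; no ring), on a double-bonded chain carbon bound to a double-bonded chain carbon. For the measured compounds named here, no step between measured compounds exists here, so nothing in the data tells how such a change moves the read-out.

Given that compound 2 sits at the limit, the step from compound 2 to compound 3 is expected to be a step that the limit leaves unreadable from compound 2 to compound 3, that is, no change beyond the scatter, and most likely another limit. Compound 3 is estimated at 150000 nM in this assay, with a range from 60000 nM to 400000 nM.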

Compound 3, half-maximal inhibitory concentration: > 100000 nM
Compound 3 was reported as a limit (the forecaster's own chance of this, stated with the estimate: 85%); the middle value lies beyond the limit too.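

No step can be read between compound 2 and compound 3, as both are reported only as a limit of the assay: the limit of > 100000 nM in this assay, at which 3 of the 3 values shown sit.

The compounds shown leave open how the cyano group and the group that replaces it compare in this assay, and whether any compound in this series gives a numeric value there.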